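A few compounds are considered here, and "the series" means these few. Any claim that something is new, unique, unknown or untested is made for them only; others in the source may bear on it.

In a functional assay on HL-60 cells (Homo sapiens) for inhibition, read by MTT assay, with a stated time of 48 h, tested at 10 uM (on this read-out lower numbers stand for less inhibition of growth and higher numbers for more inhibition of growth at the one concentration tested), compound 1 `Cc1cc(=O)c2c(O)cc(OCc3ccco3)c([C@H]3CCN(C)C[C@H]3O)c2o1` gives 32%, while compound 2 `Cc1oc2c([C@H]3CCN(C)C[C@H]3O)c(O)cc(O)c2c(=O)c1C(O)c1ccc(Cl)cc1` gives 2%, the lower of the two numbers and a gap beyond the scatter. Compound 3 `Cc1oc2c([C@H]3CCN(C)C[C@H]3O)c(O)cc(O)c2c(=O)c1C(O)c1c(Cl)cccc1Cl` has not yet been measured. It carries 2,6-dichlorophenyl in place of 4-chlorophenyl on a saturated chain carbon bound to an aromatic carbon and an oxygen on a saturated carbon. Within the data shown here, no measured pair shows what such a change does, so no step beyond the scatter is expected in this assay. The expected step is a number 4 percentage points higher from compound 2 to compound 3 (within the scatter). For compound 3 the estimated value is 6%, with an expected range of 0% to 18%.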

Compound 3, percent growth inhibition at one concentration: 14%
Compound 3: middle estimate off by 8 percentage points, on the low side, within the range that was stated.
By their numbers in this assay, from the lowest: compound 2; then compound 3; then compound 1.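

On the saturated chain carbon bound to an aromatic carbon and an oxygen on a saturated carbon, 2,6-dichlorophenyl in place of 4-chlorophenyl gives a number 12 percentage points higher from compound 2 to compound 3 (beyond the scatter) in this assay. Among these compounds, this is the first pair differing in one place, and it shows that the group on this carbon can move the read-out, though only by a modest step. Nothing measured here accounts for the step.
On these data alone, whether 2-chlorophenyl alone would give the same step remains open. So does the effect of an unsubstituted phenyl, a pyridine or a carboxylic acid on this carbon.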